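Adding a second chloro to the anilide ring of compound 1

A few compounds are considered here, and "the series" means these few. Any claim that something is new, unique, unknown or untested is made for them only; others in the source may bear on it.

Compound 1 `C[C@H](NC(=O)Nc1cccc(Cl)c1)c1ccccc1` is an aryl urea. In an ADME assay on the whole organism with Oryza sativa as the target, tested at 10 uM (a lower number here means a stronger effect, a higher number a weaker effect of the compound at the concentration tested), compound 1 gives 103%, the highest of the two numbers recorded, though the nearest neighbour lies within the scatter. Within the data shown here, that neighbour is compound 2 `C[C@H](NC(=O)Nc1cccc(Br)c1)c1ccccc1`, which in this assay gives 99%; the one recorded step, a number 4 percentage points lower from compound 1 to compound 2 (within the scatter), swaps bromo in place of chloro on an aromatic carbon and changes nothing beyond the scatter.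

Compound 3 `C[C@H](NC(=O)Nc1cc(Cl)ccc1Cl)c1ccccc1` is not yet measured. It differs from compound 1 by chloro in place of hydrogen on an aromatic carbon, the new group sitting ortho to a large group and para to a chloro group. Among the measured compounds shown here, no measured step covers the addition of a halogen to a position that was hydrogen; the only step, a number 4 percentage points lower from compound 1 to compound 2 (within the scatter), exchanges one halogen for another and stays within the scatter. With so little to go on, the expectation is that compound 3 behaves much like compound 1, with the step of a number 5 percentage points lower from compound 1 to compound 3 (within the scatter) expected to lie within the scatter. In this assay compound 3 is therefore estimated at 98%, with a likely range from 84% to 110%.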

Compound 3, a percentage reported as activity, at one concentration (the size of the read-out at that concentration, not a potency): 100%
Beside the measured number, compound 3's estimate is 2 percentage points below it; measured number inside the range.
By their numbers in this assay, from the lowest: compounds 2, 3 and 1 (each within the scatter of the next).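

In this assay, among these compounds, the place ortho to a large group and para to a chloro group takes chloro in place of hydrogen with a number 3 percentage points lower from compound 1 to compound 3 (within the scatter) and this is the first recorded step that adds a halogen where there was none, rather than exchanging one halogen for another. Both recorded changes to compound 1, the exchange and the addition, therefore stay within the scatter, so at this position a chloro in place of hydrogen shows no effect that can be told apart from repeated measurement. No measured evidence is available that bears on this result.

Going by these compounds, it remains open whether any group at this position would move the number beyond the scatter, for instance an amine or a methoxy in place of the new chloro. Also open is whether a carboxylic acid or a longer chain placed elsewhere on the core of compound 1 would shift the read-out at all, since the steps shown so far involve only halogens on a single ring.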